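The source may hold more compounds than are shown below. What is called first, only, known or untested is meant among the compounds shown, and "the series" means these compounds.

In a functional assay on HCT-116 cells (Homo sapiens) for inhibition, read by CCK-8 assay, with a stated time of 72 h, tested at 2 uM (a lower number here means less inhibition of growth, a higher number more inhibition of growth at the concentration tested), compound 1 `Cc1cc(C)cc(SCc2ccc(/C=C/C(=O)Nc3ccccc3N)cc2)c1` gives 7.98%, compound 2 `CCc1ccc(SCc2ccc(/C=C/C(=O)Nc3ccccc3N)cc2)cc1` gives 3.29% and compound 3 `Cc1ccc(SCc2ccc(/C=C/C(=O)Nc3ccccc3N)cc2)cc1` gives 6.23%. Compound 3 therefore stands within the scatter of both other compounds. Compound 4 `Nc1ccccc1NC(=O)/C=C/c1ccc(CSc2cccc3ccccc23)cc1` differs from it by naphthalen-1-yl in place of 4-methylphenyl on a sulfur. Two measured steps change the group on that sulfur: a number 1.8 percentage points lower from compound 1 to compound 3 (within the scatter) and a number 4.7 percentage points lower from compound 1 to compound 2 (within the scatter). The step of a number 2.9 percentage points higher from compound 2 to compound 3 (within the scatter) changes the same group at its chain. None of these brings in naphthalen-1-yl, so a direct precedent is lacking. With all three steps small, no step beyond the scatter is expected in this assay. The expected step is a number 0.8 percentage points higher from compound 3 to compound 4 (within the scatter). For compound 4 the estimated value is 7%, with an expected range of 1% to 17%.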

Compound 4, percent growth inhibition at one concentration: 11%
Compound 4: middle estimate off by 4 percentage points, on the low side; the measured number falls inside the stated range.
By their numbers in this assay, from the lowest: compounds 2, 3, 1 and 4 (each within the scatter of the next).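

On the sulfur, the change from one six-membered aromatic ring of carbon only to the two of naphthalen-1-yl gives no separation in this assay: a number 4.8 percentage points higher from compound 3 to compound 4 (within the scatter) and a number 7.7 percentage points higher from compound 2 to compound 4 (within the scatter) and a number 3 percentage points higher from compound 1 to compound 4 (within the scatter) all stay within the scatter. This place therefore accepts the 10-carbon naphthalen-1-yl as well as the smaller groups, without a reading that sets it apart from them. No supporting data bear on this result. Still open, from the compounds shown here alone, is whether a ring carrying an amine or a carboxylic acid, or a pyridine ring, on the sulfur would give a step beyond the scatter.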